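The source may report more compounds than this note shows. Statements on the series, on what has been measured and on what is new or still open speak of the compounds shown alone.

Measured so far in a functional assay on K562 cells (Homo sapiens) for cytotoxicity, read by MTT assay, with a stated time of 72 h (on this read-out higher numbers stand for weaker inhibition and lower numbers for stronger inhibition), are two compounds
- compound 1 `Oc1ccc(C2C/C(=N\NC(=S)N3CCOCC3)c3ccc(O)cc3O2)cc1` with 29400 nM
- compound 2 `Oc1ccc(C2C/C(=N\NC(=S)N3CCCC3)c3ccc(O)cc3O2)cc1` with 17300 nM

For the measured compounds named here, compound 2 holds one of only two numbers, and it stands within the scatter of compound 1. Next comes compound 3 `CCCN(CCC)C(=S)N/N=C1\CC(c2ccc(O)cc2)Oc2cc(O)ccc21`, which carries dipropylamino in place of pyrrolidin-1-yl on a thiocarbonyl carbon, and the full count of that change is dipropylamino in place of pyrrolidin-1-yl on a thiocarbonyl carbon for reference. Going by the values given here, the one measured step that bears on this change is a 1.7-fold lower number from compound 1 to compound 2 (0.23 log units; within the scatter) and it is a swap on the same thiocarbonyl carbon. On that small step alone, no change beyond the scatter is expected for compound 3 in this assay and no firm direction can be given. Among the compounds with values here, no measured compound has an open chain on this carbon, which leaves the expectation loosely founded. The estimated move is a 1.2-fold lower number from compound 2 to compound 3 (0.09 log units; within the scatter) and it is expected to stay small. For compound 3 the estimated value is 14000 nM with an expected range of 6000 nM to 35000 nM for now.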

Compound 3, half-maximal inhibitory concentration: 12400 nM
Beside the measured number, compound 3's estimate is 1.1-fold (0.05 log units) above it, within the range that was stated.
By their numbers in this assay, from the lowest: compounds 3, 2 and 1 (each within the scatter of the next, the first and the last beyond it).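

Notes on the thiocarbonyl carbon: in this assay, dipropylamino is the first open-chain group at this position, and replacing pyrrolidin-1-yl with it gives a 1.4-fold lower number from compound 2 to compound 3 (0.14 log units; within the scatter), so a ring on this carbon is not shown to be needed to retain the activity seen with compound 2. Against morpholin-4-yl, the same group gives a 2.4-fold lower number from compound 1 to compound 3 (0.37 log units; beyond the scatter), the first step in the series beyond the scatter, though only a modest one, so the position can register a difference between the groups placed on it, even though neither single step from compound 2 does so. No measured evidence on hand accounts for that difference.

For the compounds shown here, with only three groups compared at one position, it remains open whether a longer chain such as dibutylamino, or a simple dimethylamino group, would extend the modest separation from compound 1 or leave the numbers within the scatter of compound 3. Also unresolved is how a six-membered ring such as piperidin-1-yl or 4-methylpiperazin-1-yl on the same carbon would compare with morpholin-4-yl and with the open chain.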